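This account rests on a few compounds, and the source may have more. Where it says the series, first, only, none or still open, it means among the compounds named here.

Measured compounds in a functional assay on the whole organism (blood) with Rattus norvegicus as the target, with stated times of 24 h and 1 h, at a dose of 15 mg/kg by the intraperitoneal route; on this read-out higher numbers stand for a stronger effect at the one dose given and lower numbers for a weaker effect:
Compound 1 `O=C(NC[C@@H]1C[C@@H]2C=C[C@@H]1C2)NS(=O)(=O)N1CCC(CCNC(=O)c2cnsc2)CC1` gives 14%.
Compound 2 `O=C(NC[C@@H]1C[C@@H]2C=C[C@@H]1C2)NS(=O)(=O)N1CCC(CCNC(=O)c2cscn2)CC1` gives 37%.
Compound 3 `O=C(NC[C@@H]1C[C@@H]2C=C[C@@H]1C2)NS(=O)(=O)N1CCC(CCNC(=O)c2cnccc2Cl)CC1` gives 12%.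

Compound 3 has the lowest number of the three in this assay, though its gap to compound 1 is within the scatter, and only compound 2 stands clearly apart from it, as the step of a number 25 percentage points lower from compound 2 to compound 3 (beyond the scatter) shows. Compound 4 `O=C(NC[C@@H]1C[C@@H]2C=C[C@@H]1C2)NS(=O)(=O)N1CCC(CCNC(=O)c2nc3ccccc3s2)CC1` differs from compound 3 in one place: 1,3-benzothiazol-2-yl in place of 4-chloropyridin-3-yl on a carbonyl carbon.

Within the data shown here, no measured step exchanges this group, so no step bears directly on it. The closest indication is a number 23 percentage points higher from compound 1 to compound 2 (beyond the scatter), where a five-membered aromatic ring with two hetero atoms gave a modest rise, and a number 2 percentage points lower from compound 1 to compound 3 (within the scatter), which stayed within the scatter. On this basis a modest rise is expected for compound 4, though with little certainty, with the step estimated as a number 10 percentage points higher from compound 3 to compound 4 (within the scatter). Compound 4 is therefore estimated at 22% in this assay, with a range from 6% to 45%.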

Compound 4, a percentage reported as activity, at one dose (the size of the read-out at that dose, not a potency): 34%
The estimate for compound 4 lay 12 percentage points below the measured number; the range from low to high includes it.
By their numbers in this assay, from the lowest: compounds 3 and 1 (each within the scatter of the next); then compounds 4 and 2 (each within the scatter of the next).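

In this assay, 1,3-benzothiazol-2-yl, with its added six-membered aromatic ring of carbon only, is accepted on the carbonyl carbon: replacing 4-chloropyridin-3-yl gives a clear gain (a number 22 percentage points higher from compound 3 to compound 4 (beyond the scatter)), and replacing 1,2-thiazol-4-yl gives a similar one (a number 20 percentage points higher from compound 1 to compound 4 (beyond the scatter)). Set against 1,3-thiazol-4-yl, the same group shows no separable change (a number 3 percentage points lower from compound 2 to compound 4 (within the scatter)), so the higher level seen so far is now reached by two groups rather than one. Nothing measured here explains why these two groups stand apart from the other two.

Going by these compounds, whether a 1,3-benzoxazol-2-yl or a plain phenyl on the same carbonyl carbon would reach that level stays open. So does whether a longer chain leading to the amide would keep it.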